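Dropping the Para Chloro from a Sulfonamide Acetamide

A few compounds are considered here, and "the series" means these few. Any claim that something is new, unique, unknown or untested is made for them only; others in the source may bear on it.

Of the compounds shown here, three have been measured in a functional assay on A549 cells (Homo sapiens) for antiproliferative activity, read by MTT assay, with a stated time of 48 h; on this read-out lower numbers stand for stronger inhibition and higher numbers for weaker inhibition. Compound 1 `Cc1ncc([N+](=O)[O-])n1CC(=O)NS(=O)(=O)c1ccc(F)cc1` gives 1.26 ug/mL, and compound 3 `Cc1ncc([N+](=O)[O-])n1CC(=O)NS(=O)(=O)c1ccc(Br)cc1` gives 3.03 ug/mL; the two share a core and differ only in the halogen on the sulfonyl aryl ring, and the step of a 2.4-fold higher number from compound 1 to compound 3 (0.38 log units; beyond the scatter) is modest but beyond the scatter. Compound 2 `O=C(Cc1ccc(F)cc1)NS(=O)(=O)c1ccc(Cl)cc1`, built on a different core, gives 6.28 ug/mL, the highest of the three numbers, beyond the scatter from both of the others.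

The next compound, compound 4 `O=C(Cc1ccc(F)cc1)NS(=O)(=O)c1ccccc1`, is derived from compound 2 by a single change: hydrogen in place of chloro on an aromatic carbon. Within the data shown here, no measured step removes a halogen altogether. Among the measured compounds shown here, the only step that bears on the question is the halogen swap from compound 1 to compound 3 on the same aryl ring, in which the smaller halogen carried the lower number; its size was a 2.4-fold higher number from compound 1 to compound 3 (0.38 log units; beyond the scatter). Whether taking the halogen away entirely follows that trend is not shown, and the core of compound 4 is not the core of compound 1.

The step from compound 2 to compound 4 in this assay is therefore expected to be small, most likely a 1.1-fold higher number from compound 2 to compound 4 (0.05 log units; within the scatter), within the scatter. Compound 4 is expected to give about 7 ug/mL, with a range from 3 ug/mL to 16 ug/mL.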

Compound 4, half-maximal inhibitory concentration: 10.1 ug/mL
Beside the measured number, compound 4's estimate is 1.4-fold (0.16 log units) below it, and the stated range covers the measured number.
By their numbers in this assay, from the lowest: compound 1; then compound 3; then compounds 2 and 4 (each within the scatter of the next).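

In this assay, hydrogen in place of chloro on the aromatic carbon para to a large group gives a 1.6-fold higher number from compound 2 to compound 4 (0.21 log units; within the scatter), so within the scatter the sulfonyl aryl ring of compound 2 does not depend on that chloro for its number. Among these compounds, until now the only change seen on such a ring was one halogen swapped for another on a different core, a 2.4-fold higher number from compound 1 to compound 3 (0.38 log units; beyond the scatter), whereas this step shows a halogen removed altogether, and 4-chlorophenyl and phenyl cannot be told apart here. Nothing shown gives a measured property of either compound that would bear on this result.

The compounds shown leave open whether the same change would also stay within the scatter on the core of compound 1, which appears here only with fluoro and bromo on the aryl ring. They also leave open whether a group of another kind at this position, such as an amine, a methoxy group or a carboxylic acid, would carry the number in this series beyond the scatter in either direction.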